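The source may hold more compounds than are shown below. What is called first, only, known or untested is meant among the compounds shown, and "the series" means these compounds.

Measured compounds:
Compound 1 `C=CCn1c(=O)/c(=C\c2ccc(Cl)c(Cl)c2)[nH]c(=O)/c1=C\c1ccccc1OC`: in a functional assay on BGC-823 cells (Homo sapiens) for cytotoxicity, read by CCK-8 assay, with a stated time of 72 h (on this read-out lower numbers stand for stronger inhibition and higher numbers for weaker inhibition), compound 1 gives "not active" (no number reported).
Compound 2 `C=CCn1c(=O)/c(=C\c2ccccc2C(F)(F)F)[nH]c(=O)/c1=C\c1ccccc1OC`: in this assay compound 2 gives 5100 nM.

Going by the values given here, compound 2 is the only compound here with a number; compound 1 is reported only as not active, with no figure. Compound 3 `C=CCn1c(=O)/c(=C\c2ccc(F)c(Br)c2)[nH]c(=O)/c1=C\c1ccccc1OC` has not yet been measured. It differs from compound 2 in one place: 3-bromo-4-fluorophenyl in place of 2-(trifluoromethyl)phenyl on a double-bonded chain carbon bound to an aromatic carbon. Among the compounds with values here, no step between two measured compounds is available to guide the size of this change, so any forecast rests on the bare fact that the only other compound tested gave no number at all. On that basis the step from compound 2 to compound 3 is expected to go toward weaker inhibition in this assay, by more than the scatter, with a fair chance that only a limit is reported. The value expected for compound 3 in this assay is 15000 nM, within 4000 nM to 60000 nM, which corresponds to the estimated step of a 2.9-fold higher number from compound 2 to compound 3 (0.47 log units; beyond the scatter).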

Compound 3, half-maximal inhibitory concentration: "not active" (no number reported)
Nothing numeric was reported for compound 3; no gap can be computed for the estimate.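

In this assay compound 3 gives "not active" (no number reported), and compound 2 alone carries a number, so no step can be read between these compounds. Nothing shown offers an explanation for this result. The compounds shown leave open how strongly inhibition depends on the aromatic group that changes among them.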